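The compounds below may be only part of what the source reports. "The series", "measured", "known", "first", "only" and "open" are said of these compounds alone.

Going by the values given here, compound 3 `O=c1cc(-c2cc(Br)c(Br)[nH]2)oc2ccccc12` is the one member of this small set for which a number rather than a limit is in hand: in a functional assay on PA-1 cells (Homo sapiens) for cytotoxicity, read by MTT assay, with stated times of 6 h and 48 h (on this read-out higher numbers stand for weaker inhibition and lower numbers for stronger inhibition), compound 3 gives 410 nM. Compound 2 `O=C(/C=C/c1cc(Br)c(Br)[nH]1)c1ccccc1` carries the same dibrominated five-membered ring joined to an open-chain part instead of the core of compound 3; how the two cores differ is not broken down here. In this assay compound 2 reaches only the limit of the assay, >= 100000 nM. Compound 1 `Cn1c(/C=C/C(=O)c2ccccc2)cc(Br)c1Br` is compound 2 with methyl in place of hydrogen on an aromatic nitrogen. In this assay compound 1 also gives only the limit, >= 100000 nM. The step that the two limits leave unreadable from compound 2 to compound 1 therefore cannot be read, because of the limit of >= 100000 nM in this assay, at which 2 of the 3 values shown sit. Compound 4 `Cn1c(-c2cc(=O)c3ccccc3o2)cc(Br)c1Br`, still to be measured, stands to compound 3 as compound 1 stands to compound 2, with methyl in place of hydrogen on an aromatic nitrogen: the same change at the same place. Among the compounds with values here, no measured step tells how large this change is, so any forecast rests on the value of compound 3 alone. From that starting point the step of a 2.9-fold higher number from compound 3 to compound 4 (0.47 log units; beyond the scatter) is expected, a modest loss. Compound 4 is thus estimated at 1200 nM, within a range from 300 nM to 6000 nM.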

Compound 4, half-maximal inhibitory concentration: 600 nM
The estimate for compound 4 lay 2.0-fold (0.30 log units) above the measured number; the range from low to high includes it.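

In this assay, methyl in place of hydrogen on an aromatic nitrogen gives a 1.5-fold higher number from compound 3 to compound 4 (0.17 log units; within the scatter), so on the core of compound 3 this change makes no difference that can be told from the usual scatter of repeated measurements. Going by these compounds alone, the same change on the open-chain compounds offers no size to set beside it, and the step between compound 2 and compound 1 cannot be read because both values are limits of the assay: the limit of >= 100000 nM in this assay, at which 2 of the 4 values shown sit. Only one readable step therefore stands here, which shows how the change behaves on one core but neither confirms nor rules out that it would behave alike on the other.

The compounds shown leave open what an ethyl group, a longer chain, or a chain ending in an amine or a carboxylic acid would do in place of the methyl on that nitrogen. They also leave open what a chloro group in place of either bromo group would do in this assay.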